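Working notes on a thioether series against pro-cathepsin H

The source may report more compounds than this note shows. Statements on the series, on what has been measured and on what is new or still open speak of the compounds shown alone.

Measured compounds:
- compound 1, `O=c1nc(SCc2ccccc2)nc(SCc2ccc([N+](=O)[O-])cc2)[nH]1`: compound 1 gives "not determined" (no result reported) in an assay for inhibition of Pro-cathepsin H (Homo sapiens), read by fluorescence, tested at 50 uM; on this read-out higher numbers stand for more inhibition at the one concentration tested (going by the name of the read-out) and lower numbers for less inhibition
- compound 2, `N#Cc1cccc(CSc2nc(SCc3ccccc3)nc(=O)[nH]2)c1`: compound 2 gives "not determined" (no result reported) in this assay
- compound 3, `N#Cc1ccc(CSc2nc(SCc3ccccc3)nc(=O)[nH]2)cc1`: compound 3 gives 1.55% in this assay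

Among the measured compounds shown here, compound 3 holds the only number in the set; compounds 1 and 2 carry no result, so compound 3 cannot be ranked against them. On its own reading, compound 3 sits at a very low level of inhibition in this assay.

Compound 4, `O=c1nc(SCc2ccccc2)nc(SCC2CCC2)[nH]1`, differs from compound 3 by cyclobutyl in place of 4-cyanophenyl on a saturated chain carbon bound to a sulfur. For the measured compounds named here, no step between two measured compounds exists, so no gauge of how such a change moves the read-out is available. The step from compound 3 to compound 4 is expected to be a number 1.5 percentage points higher from compound 3 to compound 4 (within the scatter), that is, none beyond the scatter. Compound 4 is estimated at 3%, within -7% to 13%.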

Compound 4, a percentage reported as inhibition, at one concentration (the size of the read-out at that concentration, not a potency): 1.57%
Beside the measured number, compound 4's estimate is 1.4 percentage points above it; measured number inside the range.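

Cyclobutyl in place of 4-cyanophenyl on a saturated chain carbon bound to a sulfur gives a number 0 percentage points higher from compound 3 to compound 4 (within the scatter) in this assay and is the only readable step in the series. At this position, the read-out does not separate the aromatic ring and its nitrile from a saturated carbon ring, and both compounds sit at a very low level of inhibition. No evidence on hand bears on this result.

As far as these compounds go, whether an amine or a carboxylic acid in the same place would move the read-out stays open. Compound 1 and compound 2 carry no result, so they offer no comparison.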